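Removing the fluoro from the aryl piperazine of compound 3

A few compounds are considered here, and "the series" means these few. Any claim that something is new, unique, unknown or untested is made for them only; others in the source may bear on it.

For the measured compounds named here, compound 3 `Nc1scc(CN2CCN(c3ccc(F)c(Cl)c3)CC2)c1C(=O)c1ccc(Cl)cc1` gives -60% in a functional assay on CHO cells with adenosine receptor A1 (Homo sapiens) as the target, read by cAMP accumulation and immunoassay, with a stated time of 6 min, tested at 1 uM (a higher number here means a weaker effect of the compound at the concentration tested, a lower number a stronger effect), the highest of the three numbers measured so far. Compound 2 `Nc1scc(CN2CCN(c3cc(F)cc(F)c3)CC2)c1C(=O)c1ccc(Cl)cc1` gives -66%; a number 6 percentage points higher from compound 2 to compound 3 (within the scatter). Compound 1 `Nc1scc(CN2CCN(c3cccc(F)c3)CC2)c1C(=O)c1ccc(Cl)cc1` gives -86%; a number 26 percentage points higher from compound 1 to compound 3 (beyond the scatter). Compound 4 `Nc1scc(CN2CCN(c3cccc(Cl)c3)CC2)c1C(=O)c1ccc(Cl)cc1` differs from compound 3 by hydrogen in place of fluoro on an aromatic carbon. Going by the values given here, the one measured step that adds a fluoro to this ring is a number 20 percentage points higher from compound 1 to compound 2 (beyond the scatter), which points to the number moving back down when a fluoro is taken away; the step of a number 26 percentage points higher from compound 1 to compound 3 (beyond the scatter) covers this same fluoro together with the chloro. A modest step down in this assay is therefore expected, a number 15 percentage points lower from compound 3 to compound 4 (beyond the scatter). Compound 4 is estimated at -75%, within -92% to -55%.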

Compound 4, a percentage reported as activity, at one concentration (the size of the read-out at that concentration, not a potency): -59%
Compound 4: the middle estimate sits 16 percentage points below what was measured, and the stated range covers the measured number.
By their numbers in this assay, from the lowest: compound 1; then compounds 2, 3 and 4 (each within the scatter of the next).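

Taking the fluoro off the 3-chloro-4-fluorophenyl group, at the place ortho to a chloro group, leaves this assay without a readable change, a number 1 percentage points higher from compound 3 to compound 4 (within the scatter). The 3-chlorophenyl group of compound 4 also stands level with the 3,5-difluorophenyl group, a number 7 percentage points higher from compound 2 to compound 4 (within the scatter), whereas chloro in place of fluoro on the 3-fluorophenyl group gives a number 27 percentage points higher from compound 1 to compound 4 (beyond the scatter). The effect of a fluoro on this ring therefore depends on what else the ring carries: the same change on two cores in this assay, a number 20 percentage points higher (beyond the scatter) from compound 1 to compound 2 and a number 1 percentage points lower (within the scatter) from compound 4 to compound 3, 21 percentage points apart, beyond the scatter of two such steps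

On these data alone, what a methoxy or an amine would do at this place stays open. So does whether compound 2, compound 3 and compound 4 share a level that other substituents can move.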